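A Dipropylamino Group Replaces the Arylamino Group

A few compounds are considered here, and "the series" means these few. Any claim that something is new, unique, unknown or untested is made for them only; others in the source may bear on it.

Measured so far in a functional assay on MCF7 cells (Homo sapiens) for inhibition, read by sulforhodamine B assay; on this read-out higher numbers stand for weaker inhibition and lower numbers for stronger inhibition:
Compound 1 `Cc1ccc(NC2=CC(=O)c3c(nc4n3[C@H]3OC[C@@H](O)[C@H]3OC4)C2=O)cc1` gives > 4000 nM, which is a limit of the assay.
Compound 2 `CCOc1ccc(NC2=CC(=O)c3c(nc4n3[C@H]3OC[C@@H](O)[C@H]3OC4)C2=O)cc1` gives > 4000 nM, also a limit.
Compound 3 `CCCc1ccc(NC2=CC(=O)c3c(nc4n3[C@H]3OC[C@@H](O)[C@H]3OC4)C2=O)cc1` gives > 4000 nM, again a limit.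

Compound 1 therefore stands at the same limit as the other two, and no order among them can be read. The steps a step that the two limits leave unreadable from compound 1 to compound 2, a step that the two limits leave unreadable from compound 1 to compound 3 and a step that the two limits leave unreadable from compound 2 to compound 3 remain unreadable because of the limit of > 4000 nM in this assay, at which 3 of the 3 values shown sit.

Compound 4 `CCCN(CCC)C1=CC(=O)c2c(nc3n2[C@H]2OC[C@@H](O)[C@H]2OC3)C1=O` differs from compound 1 by dipropylamino in place of (4-methylphenyl)amino on a double-bonded ring carbon. Going by the values given here, none of the measured steps touches this part of the molecule, so no size of step can be drawn from them. Compound 4 is expected to give about 8000 nM, within 3000 nM to 30000 nM. The expected step that the limit leaves unreadable from compound 1 to compound 4 is thus estimated to be unreadable or small.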

Compound 4, half-maximal inhibitory concentration: > 16000 nM
Compound 4 ended at the assay's limit; the forecaster's own chance of this, stated with the estimate: 75%; middle value at least 2.0-fold (0.30 log units) from the limit.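

Compound 1 and compound 4 both give only limits of the assay, so the step between them cannot be read. The compounds shown leave open how strongly any of them inhibits these cells.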